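Amide-side amine variation on a shared benzophenone-type series

This account rests on a few compounds, and the source may have more. Where it says the series, first, only, none or still open, it means among the compounds named here.

Working notes on three measured compounds and one still open. The compounds share one core; they differ only in the group attached at the outer amide carbonyl. Compound 1 is `CN(C(=O)CNC(=O)CN1CCCCC1)c1ccc(Cl)cc1C(=O)c1ccccc1Cl`; in a functional assay on the whole organism for antagonist activity, with Mus musculus as the target (a lower number here means that less compound is needed, a higher number that more compound is needed for the effect), compound 1 gives 7.5 mg/kg. Compound 2 is `CN1CCN(CC(=O)NCC(=O)N(C)c2ccc(Cl)cc2C(=O)c2ccccc2Cl)CC1` and gives 59 mg/kg. Compound 3 is `CC(C)C(=O)NCC(=O)N(C)c1ccc(Cl)cc1C(=O)c1ccccc1Cl` and gives 6 mg/kg. Among these three numbers compound 1 stands second highest: its nearest neighbour is compound 3, its furthest compound 2. The step of a 1.3-fold lower number from compound 1 to compound 3 (0.10 log units; within the scatter) lies within the scatter, whereas a 7.9-fold higher number from compound 1 to compound 2 (0.90 log units; beyond the scatter) and a 9.8-fold lower number from compound 2 to compound 3 (0.99 log units; beyond the scatter) are both beyond it.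

Compound 4 is `CN(C)CC(=O)NCC(=O)N(C)c1ccc(Cl)cc1C(=O)c1ccccc1Cl`, not yet measured in this assay. Relative to compound 1 the change is dimethylamino in place of piperidin-1-yl on a saturated chain carbon bound to a carbonyl carbon.

Bearing on this are the two steps from compound 1: the small one to compound 3 and the clearly larger one to compound 2. Both compound 1 and compound 4 carry a tertiary amine at the same place, and compound 3 shows that a smaller group at this position leaves the number essentially unchanged, given a 1.3-fold lower number from compound 1 to compound 3 (0.10 log units; within the scatter). The expected step is therefore a 1.1-fold higher number from compound 1 to compound 4 (0.03 log units; within the scatter), within the scatter. Compound 4 is estimated at 8 mg/kg, with a range from 3 mg/kg to 25 mg/kg.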

Compound 4, dose for half-maximal effect: 2.6 mg/kg
The estimate for compound 4 lay 3.1-fold (0.49 log units) above the measured number; the measured number lies below the stated range.
By their numbers in this assay, from the lowest: compound 4; then compounds 3 and 1 (each within the scatter of the next); then compound 2.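

In this assay, the amine on a saturated chain carbon bound to a carbonyl carbon is not a matter of indifference even between two groups without a second ring nitrogen: dimethylamino in place of piperidin-1-yl gives a step beyond the scatter (a 2.9-fold lower number from compound 1 to compound 4 (0.46 log units; beyond the scatter)), a separation that compound 1 and compound 3 alone gave no sign of. An amine here can also give a lower number than the isopropyl series member (a 2.3-fold lower number from compound 3 to compound 4 (0.36 log units; beyond the scatter)), although compound 1 stays within the scatter of compound 3 and compound 2 goes the other way, and the whole span across the three amines is now large (a 23-fold lower number from compound 2 to compound 4 (1.36 log units; beyond the scatter)). No measurement on hand accounts for these steps.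

The compounds shown leave open whether the number falls further with methylamino or an unsubstituted amino group, and whether pyrrolidin-1-yl falls with dimethylamino or with piperidin-1-yl. They also leave open whether morpholin-4-yl or a carboxylic acid at this place would sit near compound 2 or near compound 4.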